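The source may report more compounds than this note shows. Statements on the series, on what has been measured and on what is new or still open speak of the compounds shown alone.

Compound 1 `COc1cc(-c2nn(-c3cccc(NC(=O)Nc4cc(C(F)(F)F)cc(C(F)(F)F)c4)c3)cc2-c2ccncc2)ccc1Cl` carries a 4-chloro-3-methoxyphenyl group. In a functional assay on SK-MEL-2 cells (Homo sapiens) for inhibition, read by sulforhodamine B assay, with a stated time of 48 h (a lower number here means that less compound is tolerated, a higher number that more compound is tolerated), compound 1 gives 3710 nM. Compound 2 `O=C(Nc1cccc(-n2cc(-c3ccncc3)c(-c3ccc(Cl)c(O)c3)n2)c1)Nc1cc(C(F)(F)F)cc(C(F)(F)F)c1` differs from it only by hydrogen in place of methyl on an oxygen on an aromatic ring, and in this assay compound 2 gives 14100 nM, which is a 3.8-fold higher number from compound 1 to compound 2 (0.58 log units; beyond the scatter). Compound 3 `COc1cc(-c2nn(-c3cccc(NC(=O)Nc4ccc(Cl)c(C(F)(F)F)c4)c3)cc2-c2ccncc2)ccc1Cl` rests on a different core; the difference between the two cores is not broken down here. In this assay compound 3 gives 17500 nM. Compound 4 `O=C(Nc1cccc(-n2cc(-c3ccncc3)c(-c3ccc(Cl)c(O)c3)n2)c1)Nc1ccc(Cl)c(C(F)(F)F)c1` is derived from compound 3 by the same change as before, (hydrogen in place of methyl on an oxygen on an aromatic ring), at the same place. Because the earlier case showed a 3.8-fold higher number from compound 1 to compound 2 (0.58 log units; beyond the scatter), a step of similar size is expected here, a 2.9-fold higher number from compound 3 to compound 4 (0.46 log units; beyond the scatter). Compound 4 is therefore estimated at 50000 nM, with an expected range from 17000 nM to 140000 nM.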

Compound 4, concentration lethal to 50% of the cells: 5840 nM
The estimate for compound 4 lay 8.6-fold (0.93 log units) above the measured number, and the stated range ends above it.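

In this assay, replacing methoxy with hydroxy gives a 3.0-fold lower number from compound 3 to compound 4 (0.48 log units; beyond the scatter). On the core of compound 3 the number therefore falls, whereas on the core of compound 1 the same change made it rise, so the step did not carry over in direction between these two cores: the same change on two cores in this assay, a 3.8-fold higher number (0.58 log units; beyond the scatter) from compound 1 to compound 2 and a 3.0-fold lower number (0.48 log units; beyond the scatter) from compound 3 to compound 4, 11-fold (1.06 log units) apart, beyond the scatter of two such steps. Among the compounds shown here, with only two pairs, this shows that a step measured on one core is a poor guide for the other, but it does not show which part of the cores is responsible or how a further core would behave.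

The compounds shown leave open what other groups would do at this place. An ethoxy group or a longer chain on the oxygen, or an amine in place of the hydroxy, would be examples.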